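Dropping the fluoro from the biphenyl tail of compound 1

This account rests on a few compounds, and the source may have more. Where it says the series, first, only, none or still open, it means among the compounds named here.

Compound 1 `CN(C)CCCCCSC1=Nc2ccccc2C(CC(=O)NCc2ccccc2)N1c1ccc(-c2ccc(F)cc2)cc1`: 4180 nM
Compound 2 `O=C(CC1c2ccccc2N=C(SCCCCCN2CCCC2)N1c1ccc(-c2ccccc2)cc1)NCc1ccc(F)cc1`: 276000 nM

Two compounds from this series were tested in an assay on cells for inhibition of Voltage-dependent T-type calcium channel subunit alpha-1H (Homo sapiens), read by patch clamp; on this read-out lower numbers stand for stronger inhibition and higher numbers for weaker inhibition. Compound 1 gives 4180 nM, the lower of the two numbers. Compound 2 differs from compound 1 in several places at once; compound 2 gives 276000 nM, a much higher number that lies well beyond the scatter. Since the two structures differ in more than one place, the pair says nothing about any single change.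

Compound 3 `CN(C)CCCCCSC1=Nc2ccccc2C(CC(=O)NCc2ccccc2)N1c1ccc(-c2ccccc2)cc1` has not been measured. It differs from compound 1 in one place only: hydrogen in place of fluoro on an aromatic carbon. Seen one bond further out, a 4-fluorophenyl becomes a phenyl, para to a large group on the six-membered aromatic ring.

Among the compounds with values here, no single-change step is available to guide the expectation, so the step of a 1.7-fold higher number from compound 1 to compound 3 (0.22 log units; within the scatter) is estimated as small, toward a somewhat higher number, and close to the edge of the scatter. In this assay compound 3 is expected to give about 7000 nM, with a range from 2000 nM to 25000 nM.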

Compound 3, half-maximal inhibitory concentration: 2400 nM
Compound 3: middle estimate off by 2.9-fold (0.46 log units), on the high side, within the range that was stated.
By their numbers in this assay, from the lowest: compounds 3 and 1 (each within the scatter of the next); then compound 2.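

In this assay, hydrogen in place of fluoro on an aromatic carbon, para to a large group, gives a 1.7-fold lower number from compound 1 to compound 3 (0.24 log units; within the scatter). Within the data shown here, this is the first single-change step available, and it shows that this read-out does not separate the 4-fluorophenyl of compound 1 from the phenyl of compound 3, so the fluoro is not needed for the inhibition seen with compound 1. No measurement bears on why the two compounds fall so close together.

Still open, on these data alone, is whether the same place tolerates any larger or differently built group, such as a chloro, a methoxy, a nitrile or an amine, or whether the small size of the step holds only for the exchange of fluoro and hydrogen. Also open, as far as these compounds go, is which of the several differences between compound 1 and compound 2 goes with the much higher number of compound 2, 276000 nM, since single changes to the amine at the end of the chain or to the benzyl amide would be needed to separate them.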